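The source may hold more compounds than are shown below. What is called first, only, known or untested is meant among the compounds shown, and "the series" means these compounds.

Compound 1 `CCCOc1ccccc1-c1ncc(C(=O)O)c(=O)[nH]1` carries a free acid on the shared core; in a functional assay on the whole organism (strain Sprague-Dawley) for inhibition, with Rattus norvegicus as the target, with a stated time of 10 min (a higher number here means that more compound is needed for the effect, a lower number that less compound is needed), compound 1 gives 0.9 mg/kg. Compound 2 `CCCOc1ccccc1-c1ncc(C(=O)OCC)c(=O)[nH]1` is its ethyl ester, and in this assay compound 2 gives 5 mg/kg. Among the compounds with values here, the only step measured so far, a 5.6-fold higher number from compound 1 to compound 2 (0.74 log units; beyond the scatter), is ethyl in place of hydrogen on an oxygen next to a carbonyl group. Compound 2 thus stands at the higher of the two numbers in this assay, with compound 1 nearest. Compound 3 `CCOC(=O)c1cnc(-c2ccccc2SCC)[nH]c1=O` keeps the ethyl ester of compound 2 and differs only on the six-membered aromatic ring of carbon only: ethylsulfanyl in place of propoxy on an aromatic carbon. Within the data shown here, no measured step bears on this change; the single step known concerns the ester and not the substituent on the aromatic ring, so the expectation rests on the change itself as counted. For compound 3 in this assay the expected step is a 1.2-fold higher number from compound 2 to compound 3 (0.08 log units; within the scatter), within the scatter. Compound 3 is estimated at 6 mg/kg, with a range from 2 mg/kg to 18 mg/kg.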

Compound 3, dose for 50% inhibition: > 5 mg/kg
Compound 3: only a limit was reported; the forecaster's own chance of this, stated with the estimate: 10%; the middle value lies beyond the limit too.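

Ethylsulfanyl in place of propoxy gives a number no lower from compound 2 to compound 3 (the limit leaves the size open) on the ethyl ester, the first change seen on the aromatic carbon ortho to a large group. In this assay compound 3 gives > 5 mg/kg and this is a limit, not a number. The swap therefore brings no lower number at this position, whereas the earlier step spoke only to the ester and said nothing about the substituent on the aromatic ring.

Going by these compounds, how far compound 3 lies from compound 2 stays open, as does the outcome of ethylsulfanyl on the free acid of compound 1. Also open, on these data alone, is whether a butoxy chain or an amine at this position would move the number in either direction.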